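The compounds below may be only part of what the source reports. "The series", "measured", "known", "first", "only" and "open" are said of these compounds alone.

Measured compounds and their values:
Compound 1, `CC(C)CSc1nc(N)nc2c1ncn2/C=C1/CC1(CO)CO` — > 20000 nM
Compound 2, `Nc1nc(N2CCCC2)c2ncn(/C=C3/CC3(CO)CO)c2n1` — > 24000 nM

In an ADME assay on Akata cells (Homo sapiens) for cytotoxicity, with a stated time of 7 days (on this read-out higher numbers stand for lower toxicity in this test and lower numbers for higher toxicity in this test), compound 1 gives > 20000 nM, which is a limit of the test and not a measured number (the limit of > 20000 nM in this assay, at which 1 of the 2 values shown sits). Compound 2, carrying pyrrolidin-1-yl in place of isobutylsulfanyl on an aromatic carbon, gives > 24000 nM in this assay, again only a limit (the limit of > 24000 nM in this assay, at which 1 of the 2 values shown sits). The step that the two limits leave unreadable from compound 1 to compound 2 therefore cannot be read, and compound 2 stands at the upper edge of what this assay reports, with no number to place it more exactly.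

Compound 3, `CCCCNc1nc(N)nc2c1ncn2/C=C1/CC1(CO)CO`, has not yet been measured. It differs from compound 2 as follows: butylamino in place of pyrrolidin-1-yl on an aromatic carbon. Among the measured compounds shown here, no measured step bears on this kind of exchange, since the only step available is unreadable. For the measured compounds named here, both compounds measured so far sit at limits, so nothing points to a shift beyond the scatter in either direction. Compound 3 is thus expected to give 30000 nM in this assay, within 10000 nM to 100000 nM. This estimate means a step that the limit leaves unreadable from compound 2 to compound 3, most likely again reported as a limit rather than a number.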

Compound 3, half-maximal cytotoxic concentration: > 24000 nM
Compound 3 gave a limit, no number; the forecaster's own chance of this, stated with the estimate: 85%; the middle value is on the limit's open side.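

Among the compounds shown here, the values of compound 1, compound 2 and compound 3 in this assay are all limits and not numbers, and no step between them can be read. The compounds shown leave open where the true half-maximal cytotoxic concentration of each lies, and whether exchanging isobutylsulfanyl, pyrrolidin-1-yl and butylamino changes that concentration at all.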